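This account rests on a few compounds, and the source may have more. Where it says the series, first, only, none or still open, it means among the compounds named here.

Among the compounds with values here, in a functional assay on HeLa cells (Homo sapiens) for cytotoxicity, read by MTT assay, with a stated time of 72 h, tested at 30 uM (a higher number here means more inhibition of growth at the concentration tested, a lower number less inhibition of growth), compound 2 `Cc1cccc(/C(N)=N/NC(=S)N2CCCC2)n1` gives 74.5%, the lowest of the three numbers measured so far, though its neighbours sit close. Compound 1 `Cc1cccc(/C(N)=N/NC(=S)N2CCCCC2)n1` gives 83.5%, and compound 3 `N/C(=N\NC(=S)N1CCCC1)c1ccccn1` gives 84.5%. Compound 4 `Cc1cccc(/C(N)=N/NC(=S)N2CCSCC2)n1` has not yet been measured; it differs from compound 2 by thiomorpholin-4-yl in place of pyrrolidin-1-yl on a thiocarbonyl carbon. The most relevant earlier step also exchanged the ring on the thiocarbonyl carbon: a number 9 percentage points lower from compound 1 to compound 2 (within the scatter). The other step, a number 10 percentage points higher from compound 2 to compound 3 (within the scatter), touches a different part of the molecule and says less. Within the data shown here, since the one comparable ring exchange stayed within the scatter, the expected change is a number 5.5 percentage points higher from compound 2 to compound 4 (within the scatter), nothing beyond the scatter. Compound 4 is therefore estimated to give 80%, within a range of 66% to 92%.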

Compound 4, percent growth inhibition at one concentration: 85.3%
The estimate for compound 4 lay 5.3 percentage points below the measured number, within the range that was stated.
By their numbers in this assay, from the lowest: compounds 2, 1, 3 and 4 (each within the scatter of the next, the first and the last beyond it).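

In this assay the ring on the thiocarbonyl carbon can move the number beyond the scatter: thiomorpholin-4-yl in place of pyrrolidin-1-yl gives a number 10.8 percentage points higher from compound 2 to compound 4 (beyond the scatter) as a modest step, the first beyond the scatter among these compounds. Thiomorpholin-4-yl in place of piperidin-1-yl, by contrast, gives a number 1.8 percentage points higher from compound 1 to compound 4 (within the scatter) and so separates nothing. No measurement here accounts for either step. The compounds shown leave open how morpholin-4-yl or an open-chain dimethylamino group on the thiocarbonyl carbon would compare.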